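This account rests on a few compounds, and the source may have more. Where it says the series, first, only, none or still open, it means among the compounds named here.

Measured so far in an ADME assay for permeability, using PAMPA, with a stated time of 10 h, tested at 100 ug/mL; on this read-out higher numbers stand for higher permeability and lower numbers for lower permeability:
compound 1 `Oc1ccc2cc(-c3ccc(O)c4ncccc34)oc2c1` gives 15.8 10^-6 cm/s
compound 2 `Oc1cc(O)c2cc(-c3ccc(O)c4ncccc34)oc2c1` gives 2.6 10^-6 cm/s
compound 3 `Oc1ccc2cc(-c3ccc4cccc(O)c4n3)oc2c1` gives 15.8 10^-6 cm/s

Compound 3 and compound 1 are built from the same atoms joined differently; the difference between the two cores is not broken down here. In this assay compound 3 stands level with compound 1 at the digits shown, a gap within the scatter, and the two together hold the highest numbers of the three. Compound 2 differs from compound 1 by one change, (hydroxy in place of hydrogen on an aromatic carbon). That change brought a 6.1-fold lower number from compound 1 to compound 2 (0.78 log units; beyond the scatter), a modest step but beyond the scatter.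

Compound 4 `Oc1cc(O)c2cc(-c3ccc4cccc(O)c4n3)oc2c1` has not yet been measured. It differs from compound 3 by the same change, (hydroxy in place of hydrogen on an aromatic carbon), with the same surroundings at the place of the change. From compound 3 to compound 4 the step expected in this assay is a 6.1-fold lower number from compound 3 to compound 4 (0.78 log units; beyond the scatter). This expectation rests on the measured step of a 6.1-fold lower number from compound 1 to compound 2 (0.78 log units; beyond the scatter) and on compound 3 giving 15.8 10^-6 cm/s, level with compound 1. Compound 4 is therefore estimated to give 2.6 10^-6 cm/s in this assay, with a likely range from 1.3 10^-6 cm/s to 5.5 10^-6 cm/s.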

Compound 4, apparent permeability: 13.3 10^-6 cm/s
Beside the measured number, compound 4's estimate is 5.1-fold (0.71 log units) below it; the measured number lies above the stated range.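

In this assay, hydroxy in place of hydrogen on an aromatic carbon does not carry over from one core to the other as a fixed step: the same change on two cores in this assay, a 6.1-fold lower number (0.78 log units; beyond the scatter) from compound 1 to compound 2 and a 1.2-fold lower number (0.07 log units; within the scatter) from compound 3 to compound 4, 5.1-fold (0.71 log units) apart, beyond the scatter of two such steps

The new step reads a 1.2-fold lower number from compound 3 to compound 4 (0.07 log units; within the scatter), so on this core the added hydroxy leaves the read-out within the scatter, whereas the same change on the core of compound 1 does not. These two pairs show that, within these compounds, a step measured on one core cannot simply be transferred to the other, but they do not show which difference between the cores goes with the different outcomes, nor how the change would behave on any third core.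

Still open, as far as these compounds go, is whether another group at the same place on the ring, such as an amine, a methoxy group or a carboxylic acid, would differ between the two cores in the same way. From the compounds shown here alone, it is also open whether any other core would follow compound 2 or compound 4 once the hydroxy is added.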